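Extending the ether chain on a low-toxicity scaffold

The compounds below may be only part of what the source reports. "The series", "measured", "known", "first", "only" and "open" are said of these compounds alone.

Compound 2 `CCCOc1ccc(-c2nn3c(NC4CCCC4)nccc3c2-c2ccnc(NC3CCCC3)n2)cc1` carries a propyl ether on its aromatic ring, and in an ADME assay on Vero cells (Chlorocebus sabaeus) for cytotoxicity (on this read-out lower numbers stand for higher toxicity in this test and higher numbers for lower toxicity in this test), compound 2 returns only a limit, > 20000 nM. Its methyl-ether relative, compound 1 `COc1ccc(-c2nn3c(NC4CCCC4)nccc3c2-c2ccnc(NC3CCCC3)n2)cc1`, also stops at a limit in this assay, where compound 1 gives > 40000 nM. Within the data shown here, the single measured step, a step that the two limits leave unreadable from compound 1 to compound 2, therefore says nothing about direction or size, since both ends rest on limits (the limit of > 20000 nM in this assay, at which 1 of the 2 values shown sits; (the limit of > 40000 nM in this assay, at which 1 of the 2 values shown sits)).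

Compound 3 `CCCCOc1ccc(-c2nn3c(NC4CCCC4)nccc3c2-c2ccnc(NC3CCCC3)n2)cc1` takes the chain one carbon further: methyl in place of hydrogen on a saturated chain carbon, three bonds along the chain from an oxygen on an aromatic ring. Among the measured compounds shown here, the only measured step that bears on this change is the unreadable one from compound 1 to compound 2, so no measured size can be carried forward; what the two limits do show is that neither the methyl nor the propyl ether reached measurable cytotoxicity in this assay.

On that basis compound 3 is expected to change by about a step that the limit leaves unreadable from compound 2 to compound 3, that is, to stay within the scatter of compound 2. The estimate for compound 3 in this assay is 30000 nM, with a range from 12000 nM to 80000 nM, and most likely again reported only as a limit.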

Compound 3, half-maximal cytotoxic concentration: > 40000 nM
Compound 3 was reported as a limit; the forecaster's own chance of this, stated with the estimate: 70%; at least 1.3-fold (0.12 log units) between middle value and limit.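

Compound 3 also stops at a limit in this assay, so the steps linking compound 1, compound 2 and compound 3 cannot be read in either size or direction. The compounds shown leave open where the half-maximal cytotoxic concentration of each of these three ethers lies, and whether chain length changes it at all.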